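Replacing a Sulfonyl With an Amide on the Ring Nitrogen

The source may hold more compounds than are shown below. What is called first, only, known or untested is meant among the compounds shown, and "the series" means these compounds.

This piece follows a single change to a small thiazolopyrimidine-free description: the shared core carries an aminated piperazine, and the group on that ring nitrogen is swapped. Compound 1 `Nc1nc(N2CCN(S(=O)(=O)c3ccccc3)CC2)c2nc(-c3ccc(F)cc3)sc2n1` is the starting point. In a functional assay on cells (Lymphocyte, Homo sapiens) (on this read-out lower numbers stand for stronger inhibition and higher numbers for weaker inhibition), compound 1 gives only > 10000 nM, which is a limit of the assay rather than a number, and the limit of > 10000 nM in this assay, at which 1 of the 2 values shown sits, marks where that value sits. Compound 2 `Nc1nc(N2CCN(C(=O)COc3ccc(Cl)cc3)CC2)c2nc(CCOc3ccc(F)cc3)sc2n1` has a different group on the core and a chlorinated amide on the ring nitrogen; in this assay compound 2 gives 3540 nM. Compound 3 `Nc1nc(N2CCN(C(=O)COc3ccc(F)cc3)CC2)c2nc(-c3ccc(F)cc3)sc2n1` is not yet measured. It differs from compound 1 by ((4-fluorophenoxy)methyl)carbonyl in place of phenylsulfonyl on an amine nitrogen in a ring. Going by the values given here, no measured step matches this change, so the expected direction rests on compound 2, whose amide-bearing ring nitrogen goes with a numbered value of 3540 nM. From compound 1 to compound 3 the step is expected to be an at least 1.6-fold lower number from compound 1 to compound 3 (0.22 log units; that floor lies within the scatter), a modest gain that may still leave only a limit. For compound 3 the estimate in this assay is 6000 nM, with a range from 1500 nM to 20000 nM.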

Compound 3, half-maximal inhibitory concentration: 70 nM
The estimate for compound 3 lay 86-fold (1.93 log units) above the measured number, and the stated range ends above it.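

Swapping phenylsulfonyl for ((4-fluorophenoxy)methyl)carbonyl on the amine nitrogen of the six-membered non-aromatic ring, with the rest of the molecule unchanged, gives an at least 140-fold lower number from compound 1 to compound 3 (2.15 log units; beyond the scatter), so in this assay this one position can by itself separate a compound with a readable value from one without. The counts of hydrogen-bond donors and acceptors and the net charge are the same for the group that leaves and the group that enters, so these counts do not tell the two groups apart, even though the read-out does. Compound 1 is held at a limit of the assay rather than a number, so the printed step is a floor and its true size remains unknown: the limit of > 10000 nM in this assay, at which 1 of the 3 values shown sits.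

The change removes the sulfonyl link and adds a carbonyl link, an ether oxygen and a fluorine all at once, so the compounds shown cannot say which of these parts carries the step. A phenoxyacetyl group without the fluorine, a plain benzoyl group or a small acetyl group at the same nitrogen would help to pull these parts apart.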